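Compound 4: isopropyl on the sulfonamide nitrogen

This account rests on a few compounds, and the source may have more. Where it says the series, first, only, none or still open, it means among the compounds named here.

In a functional assay on MV4-11 cells (Homo sapiens) for inhibition, with a stated time of 72 h (a higher number here means a weaker inhibitor, a lower number a stronger inhibitor), compound 1 `O=C(NO)c1ccc(CN(C2CC2)S(=O)(=O)c2cc(F)c(F)c(F)c2F)cc1` gives 400 nM. Compound 3 `COCCN(Cc1ccc(C(=O)NO)cc1)S(=O)(=O)c1cc(F)c(F)c(F)c1F` gives 660 nM, so these two share the low end of the three numbers. Compound 2 `CC(C)N(Cc1ccc(C(=O)NO)cc1)C(=O)c1c(F)c(F)c(F)c(F)c1F` stands well apart at 16400 nM.

The open step leads to compound 4 `CC(C)N(Cc1ccc(C(=O)NO)cc1)S(=O)(=O)c1cc(F)c(F)c(F)c1F`, with isopropyl in place of cyclopropyl on a sulfonamide nitrogen.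

Among the compounds with values here, one measured step bears on this nitrogen. Exchanging cyclopropyl for 2-methoxyethyl gave a 1.7-fold higher number from compound 1 to compound 3 (0.22 log units; within the scatter), so a larger change of group at this place left this assay within the scatter. Compound 2 also carries isopropyl, but it has a carbonyl in place of the sulfonyl, among other differences. Within the data shown here, no single-place step connects it to compound 4, so it sets no size for this change.

No step beyond the scatter is therefore expected in this assay. The estimated change is a 1.3-fold higher number from compound 1 to compound 4 (0.10 log units; within the scatter). For compound 4 the expected value is 500 nM, with an estimated range of 200 nM to 1300 nM.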

Compound 4, half-maximal inhibitory concentration: 1190 nM
Beside the measured number, compound 4's estimate is 2.4-fold (0.38 log units) below it, and the stated range covers the measured number.
By their numbers in this assay, from the lowest: compounds 1, 3 and 4 (each within the scatter of the next, the first and the last beyond it); then compound 2.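

In this assay, within the data shown here, the exchange of cyclopropyl for isopropyl on the sulfonamide nitrogen is the first single-place change to pass the scatter, at a 3.0-fold higher number from compound 1 to compound 4 (0.47 log units; beyond the scatter), even though the two groups match in heavy-atom count and differ in that cyclopropyl holds a ring. Among these compounds, the two open-chain groups are not separated, at a 1.8-fold higher number from compound 3 to compound 4 (0.26 log units; within the scatter), so at this nitrogen only the step from cyclopropyl to isopropyl is resolved, and it is modest. Nothing measured here accounts for that step.

As far as these compounds go, it remains open whether a cyclobutyl group or a straight propyl chain on this nitrogen would stay with cyclopropyl or with isopropyl in this assay. Also open, from the compounds shown here alone, is how a chain ending in an amine or a carboxylic acid would behave at this place.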